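A few compounds are considered here, and "the series" means these few. Any claim that something is new, unique, unknown or untested is made for them only; others in the source may bear on it.

Working notes on the series.

Compound 1 `CC[C@@H](Nc1c(Nc2cccc(C(=O)N(C)C)c2O)c(=O)c1=O)c1ccc(C)s1` and compound 2 `CCc1ccoc1[C@@H](CC)Nc1c(Nc2cccc(C(=O)N(C)C)c2O)c(=O)c1=O` share a common core and differ only in the aryl group on the saturated chain carbon bound to a nitrogen on an aromatic ring and a saturated chain carbon. In an assay on CHO cells for displacement of a labelled ligand from C-X-C chemokine receptor type 1 (Homo sapiens) (a lower number here means a stronger inhibitor, a higher number a weaker inhibitor), compound 1 gives 146 nM, while compound 2 gives 379 nM. Going by the values given here, compound 2 therefore stands at the highest of the two numbers measured so far; the only step recorded, a 2.6-fold higher number from compound 1 to compound 2 (0.41 log units; beyond the scatter), separates it from compound 1.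

Compound 3 `CC[C@@H](Nc1c(Nc2cccc(C(=O)N(C)C)c2O)c(=O)c1=O)c1cc(C2CCCC2)co1` is not yet measured. It differs from compound 2 at the same place: 4-cyclopentylfuran-2-yl in place of 3-ethylfuran-2-yl on a saturated chain carbon bound to a nitrogen on an aromatic ring and a saturated chain carbon. Among the compounds with values here, the one measured step that bears on this position, a 2.6-fold higher number from compound 1 to compound 2 (0.41 log units; beyond the scatter), was modest and shows that an aryl swap here can move the number beyond the scatter, but no measured pair speaks to a cyclopentyl substituent on the furan. The expected step of a 1.3-fold lower number from compound 2 to compound 3 (0.10 log units; within the scatter) is therefore kept small and set as none beyond the scatter, with a wide range. Compound 3 is expected to give about 300 nM in this assay, between 90 nM and 1000 nM.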

Compound 3, inhibition constant: 53 nM
Compound 3: middle estimate off by 5.7-fold (0.75 log units), on the high side; measured number outside the range, below it.
By their numbers in this assay, from the lowest: compound 3; then compound 1; then compound 2.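

In this assay the furan ring alone does not set the order: the 3-ethylfuran-2-yl of compound 2 stands above the 5-methylthiophen-2-yl of compound 1, while 4-cyclopentylfuran-2-yl gives a 2.8-fold lower number from compound 1 to compound 3 (0.44 log units; beyond the scatter), and so compound 3 has the lowest number of the three, with both its steps beyond the scatter. The swap of the furan group alone also gives a 7.2-fold lower number from compound 2 to compound 3 (0.85 log units; beyond the scatter), the largest step yet seen at this saturated chain carbon, which shows that a substituent carrying a five-membered carbon ring is accepted here and that the number at this position can move well beyond the scatter in either direction. No measurement on hand bears on why the cyclopentyl-bearing furan gives this result.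

In going from compound 2 to compound 3 both the substituent and its place on the furan change, so the shares of the two changes in the step remain unseparated. Also open, as far as these compounds go, is how far the trend runs with other groups on the furan, such as a cyclohexyl ring, a longer alkyl chain or an amine.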